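The source may hold more compounds than are shown below. What is called first, only, known or untested is meant among the compounds shown, and "the series" means these compounds.

This account follows a single change made to the shared core of compound 1, `CCC1(Cc2ccccc2)OS(=O)(=O)C=C1NCc1ccccc1`. In an ADME assay on HEL cells (Homo sapiens) for cytotoxicity, with a stated time of 3 days (on this read-out higher numbers stand for lower toxicity in this test and lower numbers for higher toxicity in this test), compound 1 gives 92000 nM, and this is the only number shown in the set. Compound 2, `CCC1(Cc2ccccc2)OS(=O)(=O)C=C1OCCCCCCc1ccccc1`, is the other measured compound; in this assay compound 2 gives < 200000 nM, which is a limit of the assay rather than a number. Among the measured compounds shown here, compound 1 therefore stands as the one measured number, and the further value shown sits at the limit of < 200000 nM in this assay, at which 1 of the 2 values shown sits.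

Compound 3, `CCC1(Cc2ccccc2)OS(=O)(=O)C=C1OCc1ccccc1`, has not yet been measured in this assay. It differs from compound 1 in one place: benzyloxy in place of benzylamino on a double-bonded ring carbon. For the measured compounds named here, no step between two measured compounds is known here, so the size of this change can only be anticipated from the structures. Compound 3 is expected to remain close to compound 1, with an expected step of a 1.1-fold higher number from compound 1 to compound 3 (0.04 log units; within the scatter) that stays within the usual scatter of the assay. The estimate for compound 3 in this assay is 100000 nM, with a range from 40000 nM to 250000 nM.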

Compound 3, half-maximal cytotoxic concentration: 200000 nM
The estimate for compound 3 lay 2.0-fold (0.30 log units) below the measured number; measured number inside the range.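

Replacing benzylamino with benzyloxy on a double-bonded ring carbon keeps the count of 8 heavy atoms and the single six-membered aromatic ring, yet in this assay it gives a 2.2-fold higher number from compound 1 to compound 3 (0.34 log units; beyond the scatter), so the read-out at this position moves towards lower toxicity in this test when only the atom that carries the benzyl group changes. Among the compounds shown here, the earlier compounds offered no step at all, and this modest one is the first size that can be read for any change at this position. Compound 2 carries a limit of the assay rather than a number, so no step involving it can be read and the effect of its longer chain on the oxygen stays unknown: the limit of < 200000 nM in this assay, at which 1 of the 3 values shown sits.

A single pair cannot tell whether the step follows the change from nitrogen to oxygen itself or the loss of the one hydrogen-bond donor, and no cause for it is given by what is shown. On these data alone, what also remains open is how a benzylthio group or a methylated benzylamino group at this same position would read in this assay.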